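A Single Fluoro Swap on Compound 1

The source may hold more compounds than are shown below. What is called first, only, known or untested is meant among the compounds shown, and "the series" means these compounds.

Compound 1 `Nc1cccn2cc(Cc3ccccc3)c(=O)nc12`: 98000 nM
Compound 2 `O=C1N=C2C=CC=CN2CC1C(O)c1cccs1`: 248000 nM

Both numbers come from a functional assay on A549 cells (Homo sapiens) for cytotoxicity, read by MTT assay, with a stated time of 24 h; a lower number here means a stronger inhibitor, a higher number a weaker inhibitor. Compound 1 stands lowest of the two at 98000 nM, so it is the stronger inhibitor of the pair. Compound 2 gives 248000 nM, and that gap lies beyond the usual scatter of repeated measurements.

Compound 3 `Nc1cccn2cc(Cc3ccc(F)cc3)c(=O)nc12` has not yet been measured. It keeps the core of compound 1 and differs in one place: fluoro in place of hydrogen on an aromatic carbon. This puts fluoro in place of hydrogen on an aromatic carbon, on the six-membered aromatic ring of carbon only, para to a large group.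

Within the data shown here, the two measured compounds differ in more than one place, so no measured step shows what a single change does. The expectation therefore starts from compound 1 at 98000 nM, and no change beyond the scatter is expected in this assay, with neither direction favoured. The estimated move is a 1.2-fold lower number from compound 1 to compound 3 (0.06 log units; within the scatter). For compound 3 the estimated value is 85000 nM, with an expected range of 40000 nM to 180000 nM.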

Compound 3, half-maximal inhibitory concentration: > 1000000 nM
Compound 3: only a limit was reported; the forecaster's own chance of this, stated with the estimate: 10%; middle value at least 11-fold (1.07 log units) from the limit.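

Fluoro in place of hydrogen on the six-membered aromatic ring of carbon only, para to a large group, gives an at least 10-fold higher number from compound 1 to compound 3 (1.00 log units; beyond the scatter) in this assay. Among these compounds, this is the first step that changes a single place, and it shows that this position is not indifferent to change: adding one heavy atom there is enough to make compound 3 the weaker inhibitor, by a margin well beyond the scatter. Compound 3 is reported only as a limit, > 1000000 nM, so the step gives a lower bound on the size of the change, not its exact size: the limit of > 1000000 nM in this assay, at which 1 of the 3 values shown sits.

The compounds shown leave open whether this weakening belongs to fluoro in particular or would follow from any group at this carbon, and a chlorine atom, a methyl group or a methoxy group in the same place would separate those two readings. Among the compounds shown here, they also leave open whether the effect is tied to this carbon at all, since fluoro is seen on only one carbon of the ring, and why the change has such an effect on the read-out remains unknown.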